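A few compounds are considered here, and "the series" means these few. Any claim that something is new, unique, unknown or untested is made for them only; others in the source may bear on it.

Measured in a functional assay on A549 cells (Homo sapiens) for antiproliferative activity, read by sulforhodamine B assay, with a stated time of 48 h; on this read-out lower numbers stand for stronger inhibition and higher numbers for weaker inhibition:
Compound 1 `COc1ccc(OC)c(/C=C/C(=O)C(=Cc2ccc(O)c(OC)c2)C(=O)/C=C/c2cc(OC)ccc2OC)c1`: 190 nM
Compound 2 `COc1ccc(OC)c(/C=C/C(=O)C(=Cc2cc(OC)c(O)c(OC)c2)C(=O)/C=C/c2cc(OC)ccc2OC)c1`: 190 nM

Level with compound 1, compound 2 stands at 190 nM. Next is compound 3 `COc1ccc(OC)c(/C=C/C(=O)C(=Cc2ccc(OC)c(O)c2)C(=O)/C=C/c2cc(OC)ccc2OC)c1`, with 3-hydroxy-4-methoxyphenyl in place of 4-hydroxy-3,5-dimethoxyphenyl on a double-bonded chain carbon bound to a double-bonded chain carbon. For the measured compounds named here, the only measured step that bears on this is no change at the digits printed from compound 1 to compound 2 (within the scatter), a methoxy in place of hydrogen on an aromatic carbon. Going by the values given here, no measured compound carries the entering group, so the support is thin. The expected change is a 1.1-fold higher number from compound 2 to compound 3 (0.02 log units; within the scatter), with no shift beyond the scatter in either direction. For compound 3 the estimate is 200 nM, with an expected range of 80 nM to 500 nM.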

Compound 3, half-maximal inhibitory concentration: 390 nM
Compound 3: the middle estimate sits 2.0-fold (0.29 log units) below what was measured, and the stated range covers the measured number.
By their numbers in this assay, from the lowest: compounds 1 and 2 (each within the scatter of the next); then compound 3.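

In this assay, the group on the double-bonded chain carbon bound to a double-bonded chain carbon proves not to be indifferent: 3-hydroxy-4-methoxyphenyl gives a 2.1-fold higher number from compound 2 to compound 3 (0.31 log units; beyond the scatter) and also a 2.1-fold higher number from compound 1 to compound 3 (0.31 log units; beyond the scatter) in the same direction. Compound 1 and compound 2 alone had shown no separation at this position. Nothing available accounts for this loss.

As far as these compounds go, whether the hydroxy is needed at all stays open. So does how an amine or a carboxylic acid in its place would read out at this position.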